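Dropping the chloro: from compound 3 to compound 4

The source may report more compounds than this note shows. Statements on the series, on what has been measured and on what is new or still open speak of the compounds shown alone.

The measured compounds and their values in a functional assay on the whole organism (strain Swiss) with Mus musculus as the target, in the maximal electroshock model, with a stated time of 1 h, at a dose of 300 mg/kg by the intraperitoneal route; a lower number here means a weaker effect, a higher number a stronger effect of the compound at the dose given:
compound 1 `CCC(C(=O)N1CCN(c2cccc(OC)c2)CC1)N1C(=O)CCC1=O`: 0%
compound 2 `CCC(C(=O)N1CCN(c2ccccc2C(F)(F)F)CC1)N1C(=O)CCC1=O`: 0%
compound 3 `CCC(C(=O)N1CCN(c2ccc(Cl)cc2)CC1)N1C(=O)CCC1=O`: 25%

Among these three, compound 3 gives the highest number in this assay, and its gaps to compound 1 and to compound 2 are both beyond the scatter. Among the measured compounds shown here, the only single-point step that has been measured here is the exchange of the aryl group on the ring nitrogen, which gave a number 25 percentage points higher from compound 1 to compound 3 (beyond the scatter).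

Compound 4 `CCC(C(=O)N1CCN(c2ccccc2)CC1)N1C(=O)CCC1=O` has not yet been measured. It differs from compound 3 by hydrogen in place of chloro on an aromatic carbon, that is, 4-chlorophenyl to phenyl. For the measured compounds named here, no measured step removes a substituent from the aryl ring outright; the step from compound 1 to compound 3 only shows that the aryl group matters to the number in this assay. On that basis a drop is expected, with the step estimated as a number 15 percentage points lower from compound 3 to compound 4 (beyond the scatter). For compound 4 the estimate in this assay is 10%, expected to lie between 0% and 25%.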

Compound 4, a percentage reported as activity, at one dose (the size of the read-out at that dose, not a potency): 75%
Compound 4: middle estimate off by 65 percentage points, on the low side, outside the stated range (above it).
By their numbers in this assay, from the lowest: compounds 1 and 2 (each within the scatter of the next); then compound 3; then compound 4.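

In this assay, the plain phenyl group outdoes all three substituted aryl groups, so the earlier lead of the 4-chlorophenyl group did not reflect any gain from the chloro. Hydrogen in place of chloro gives a number 50 percentage points higher from compound 3 to compound 4 (beyond the scatter), while hydrogen in place of trifluoromethyl gives a number 75 percentage points higher from compound 2 to compound 4 (beyond the scatter) and hydrogen in place of methoxy gives a number 75 percentage points higher from compound 1 to compound 4 (beyond the scatter), so none of these three substituents matches the bare ring, and no compound here goes against that. No measurement is at hand that explains why the bare ring gives the highest number.

Since the three substituents differ in where they sit as well as in what they are, the effect of the group cannot be separated from that of its place. From the compounds shown here alone, whether a fluoro or a methyl group on the aromatic carbon that carries the chloro in compound 3 would hold the number of compound 4 remains open.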